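Adding a second trifluoromethyl to the urea aryl

A few compounds are considered here, and "the series" means these few. Any claim that something is new, unique, unknown or untested is made for them only; others in the source may bear on it.

Compound 1 `O=C(Nc1cccc(-n2cc(-c3ccncc3)c(-c3ccc(Cl)c(O)c3)n2)c1)Nc1cccc(C(F)(F)F)c1` — 980 nM
Compound 2 `O=C(Nc1cccc(-n2cc(-c3ccncc3)c(-c3ccc(Cl)c(O)c3)n2)c1)Nc1ccc(Cl)c(Cl)c1` — 729 nM
Compound 3 `COc1cc(-c2nn(-c3cccc(NC(=O)Nc4cccc(C(F)(F)F)c4)c3)cc2-c2ccncc2)ccc1Cl` — 598 nM

Of the compounds shown here, three sharing one core have been measured in a functional assay on MDA-MB-468 cells (Homo sapiens) for inhibition, read by sulforhodamine B assay, with a stated time of 48 h; on this read-out higher numbers stand for weaker inhibition of growth and lower numbers for stronger inhibition of growth. Compound 1 stands at the highest of the three numbers; its nearest neighbour is compound 2, reached by a 1.3-fold lower number from compound 1 to compound 2 (0.13 log units; within the scatter), and the furthest is compound 3, reached by a 1.6-fold lower number from compound 1 to compound 3 (0.21 log units; within the scatter). Both steps lie within the scatter, so the three compounds are not separated by this assay.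

Compound 4 `O=C(Nc1cccc(-n2cc(-c3ccncc3)c(-c3ccc(Cl)c(O)c3)n2)c1)Nc1cc(C(F)(F)F)cc(C(F)(F)F)c1` differs from compound 1 by trifluoromethyl in place of hydrogen on an aromatic carbon. Of the measured steps, the one that bears most closely on it is the change on the same urea aryl, from compound 1 to compound 2, which also swapped substituents on that ring and moved the number only within the scatter. The change at the phenol oxygen, from compound 1 to compound 3, is at another position and also stayed within the scatter. Among the measured compounds shown here, there is no measured example of a second trifluoromethyl group on this ring, so the expectation rests on the two small steps seen so far.

The step from compound 1 to compound 4 is therefore expected to be a 1.2-fold lower number from compound 1 to compound 4 (0.06 log units; within the scatter), that is, none beyond the scatter. Compound 4 is estimated at 850 nM, with a range from 400 nM to 1800 nM.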

Compound 4, concentration for 50% growth inhibition: 265 nM
Estimate against measurement, compound 4: 3.2-fold (0.51 log units) above, outside the stated range (below it).
By their numbers in this assay, from the lowest: compound 4; then compounds 3, 2 and 1 (each within the scatter of the next).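

In this assay the urea aryl ring of compound 1 turns out to be a place where a single change can move the number beyond the scatter: trifluoromethyl in place of hydrogen on an aromatic carbon gives a 3.7-fold lower number from compound 1 to compound 4 (0.57 log units; beyond the scatter) and counts as a modest step, whereas the earlier change on the same ring, a 1.3-fold lower number from compound 1 to compound 2 (0.13 log units; within the scatter), did not leave the scatter. This is the first step shown that separates two compounds in this series, and it comes from a trifluoromethyl group entering meta to a trifluoromethyl group already on that ring. Nothing shown here accounts for the step, so it stands as an observation only.

As far as these compounds go, whether another group at this same place, such as a methoxy, a nitrile or an amine, would give a step of like size stays open. From the compounds shown here alone, it is equally open whether the second trifluoromethyl would have the same effect on the core of compound 3, which carries methyl on the oxygen of the phenol.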